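Swapping the Amine on an Acrylamide Tail

The source may report more compounds than this note shows. Statements on the series, on what has been measured and on what is new or still open speak of the compounds shown alone.

compound 1 `C=CC(=O)Nc1cc2c(N3CCc4ccccc43)ncnc2cc1O[C@@H]1CCOC1`: 2710 nM
compound 2 `CC(C)=CC(=O)Nc1cc2c(N3CCc4ccccc43)ncnc2cc1O[C@@H]1CCOC1`: 4620 nM
compound 3 `CN(C)C/C=C/C(=O)Nc1cc2c(N3CCc4ccccc43)ncnc2cc1O[C@@H]1CCOC1`: 1230 nM

In a functional assay on PC-3 cells (Homo sapiens) for antiproliferative activity, read by MTT assay, with a stated time of 72 h (on this read-out lower numbers stand for stronger inhibition and higher numbers for weaker inhibition), compound 3 gives the lowest number of the three; the steps of a 2.2-fold lower number from compound 1 to compound 3 (0.34 log units; beyond the scatter) and a 3.8-fold lower number from compound 2 to compound 3 (0.57 log units; beyond the scatter) both lie beyond the scatter, while a 1.7-fold higher number from compound 1 to compound 2 (0.23 log units; within the scatter) does not. Compound 4 `O=C(/C=C/CN1CCCC1)Nc1cc2c(N3CCc4ccccc43)ncnc2cc1O[C@@H]1CCOC1` differs from compound 3 by pyrrolidin-1-yl in place of dimethylamino on a saturated chain carbon bound to a double-bonded chain carbon. For the measured compounds named here, no measured step alters this amine directly; the steps that touch the same tail, from compound 1 and from compound 2 to compound 3, gained only modestly when the dimethylamino-bearing chain entered. A change of one small amine for another is therefore expected to give a step no larger than the scatter, a 1.2-fold lower number from compound 3 to compound 4 (0.09 log units; within the scatter). Compound 4 is estimated at 1000 nM, between 400 nM and 2500 nM.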

Compound 4, half-maximal inhibitory concentration: 1510 nM
The estimate for compound 4 lay 1.5-fold (0.18 log units) below the measured number; the range from low to high includes it.
By their numbers in this assay, from the lowest: compounds 3, 4, 1 and 2 (each within the scatter of the next, the first and the last beyond it).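

In this assay, the ring of pyrrolidin-1-yl can stand in place of dimethylamino on this saturated chain carbon with no readable effect: a 1.2-fold higher number from compound 3 to compound 4 (0.09 log units; within the scatter). The new tail separates from the 2-methylprop-1-en-1-yl compound, a 3.1-fold lower number from compound 2 to compound 4 (0.49 log units; beyond the scatter), but not from the vinyl compound, a 1.8-fold lower number from compound 1 to compound 4 (0.25 log units; within the scatter), whereas dimethylamino did clear the scatter against vinyl. Nothing available here gives a reason for these steps. Still open, as far as these compounds go, is whether a larger ring amine such as piperidine or morpholine, or a longer chain carrying the amine, would keep the number this close to that of compound 3.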